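Nitro in Place of Hydroxy on a Triazole Hydrazone

A few compounds are considered here, and "the series" means these few. Any claim that something is new, unique, unknown or untested is made for them only; others in the source may bear on it.

Two close analogues have been measured so far. Compound 1 `Oc1ccc(/C=N/n2cnnc2)cc1` carries a single hydroxy on its benzene ring; in an assay for inhibition of Alpha amylase (Homo sapiens), with a stated time of 10 min (a lower number here means a stronger inhibitor, a higher number a weaker inhibitor), compound 1 gives 2990 nM. Compound 2 `Oc1ccc(/C=N/n2cnnc2)cc1O` carries a second hydroxy on the same ring; in this assay compound 2 gives 5690 nM. The step of a 1.9-fold higher number from compound 1 to compound 2 (0.28 log units; within the scatter) therefore shows no real difference between the two. Compound 1 holds the lower of the two numbers, but its nearest neighbour, compound 2, sits within the scatter of it, so no order between them can be claimed.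

Compound 3 `O=[N+]([O-])c1ccc(/C=N/n2cnnc2)cc1` has not yet been measured. It differs from compound 1 by nitro in place of hydroxy on an aromatic carbon, para to a group of 7 heavy atoms. Among the compounds with values here, no measured step exchanges one group for another at that carbon; the only step known, from compound 1 to compound 2, adds a hydroxy elsewhere and stays within the scatter. The data give no direction for the exchange. For compound 3 the estimated step is a 1.2-fold higher number from compound 1 to compound 3 (0.07 log units; within the scatter), nothing beyond the scatter. Compound 3 is accordingly expected to give 3500 nM, with a range from 1200 nM to 10000 nM.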

Compound 3, half-maximal inhibitory concentration: 2360 nM
For compound 3 the middle estimate is 1.5-fold (0.17 log units) above the measured one; low and high end bracket the measured number.
By their numbers in this assay, from the lowest: compounds 3, 1 and 2 (each within the scatter of the next, the first and the last beyond it).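

Within the data shown here, the exchange at the aromatic carbon para to a group of 7 heavy atoms is the first measured step at this position, and in this assay it gives a 1.3-fold lower number from compound 1 to compound 3 (0.10 log units; within the scatter), so the two compounds cannot be told apart. Within this single pair, the hydroxy, with its hydrogen-bond donor, is therefore not needed for a number in this range: nitro, with 0 hydrogen-bond donors and 3 heavy atoms in place of 1, remains within the scatter of compound 1. No independent measurement is available to explain this outcome.

The compounds shown leave open whether any group at this carbon can move the number beyond the scatter, since the two groups compared here give no direction, and an amine, a carboxylic acid or a methoxy group would each test this through the same single exchange from compound 1. Also open, as far as these compounds go, is what plain hydrogen at this carbon would give, which would show whether either hydroxy or nitro contributes anything at all to the number in this assay.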